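The source may report more compounds than this note shows. Statements on the series, on what has been measured and on what is new or still open speak of the compounds shown alone.

Solubility notes on the series. In a physicochemical assay for solubility, measured as kinetic solubility (a higher number here means a more soluble compound, a lower number a less soluble compound), compound 1 `CC(=O)Nc1cc(-c2ccc(N(C)C(=O)c3c(F)cccc3Cl)c(N3CCCCC3)c2)n(C(C)C)n1` gives 1.3 ug/mL, the second highest of the three numbers; compound 2 `CC(=O)Nc1cc(-c2ccc(N(C)C(=O)c3c(F)cccc3Cl)c(N3CC4CC4C3)c2)n(C(C)C2CC2)n1` gives 0.5 ug/mL and compound 3 `CC(=O)Nc1cc(-c2ccc(N(C)C(=O)c3c(F)cccc3Cl)c(N3CC4CC4C3)c2)n(CC2CC2)n1` gives 10.1 ug/mL. Among the measured compounds shown here, the one single-point step measured so far, a 20-fold higher number from compound 2 to compound 3 (1.31 log units; beyond the scatter), concerns the chain on the pyrazole nitrogen. For the measured compounds named here, compound 4 `CC(=O)Nc1cc(-c2ccc(N(C)C(=O)c3c(F)cccc3Cl)c(OCC(F)(F)F)c2)n(C(C)C)n1` differs from compound 1 by 2,2,2-trifluoroethoxy in place of piperidin-1-yl on an aromatic carbon, a position that no measured step touches, so the step from compound 2 to compound 3 offers no guide here. Going by the values given here, with no bearing precedent, a step in this assay of modest size at most is expected from compound 1 to compound 4, a 1.9-fold higher number from compound 1 to compound 4 (0.28 log units; within the scatter). Compound 4 is accordingly estimated at 2.5 ug/mL, within a wide range of 0.6 ug/mL to 10 ug/mL.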

Compound 4, solubility: 27 ug/mL
Estimate against measurement, compound 4: 11-fold (1.03 log units) below; the measured number lies above the stated range.
By their numbers in this assay, from the lowest: compound 2; then compound 1; then compound 3; then compound 4.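

Among the compounds shown here, on the aromatic carbon ortho to the ((2-chloro-6-fluorophenyl)carbonyl)(methyl)amino group, a position no earlier step touched, this assay proves highly sensitive to the group present: 2,2,2-trifluoroethoxy in place of piperidin-1-yl gives a 21-fold higher number from compound 1 to compound 4 (1.32 log units; beyond the scatter). The two groups have the same counts of heavy atoms, donors and acceptors, so those counts do not separate them. No measurement available here bears on the cause of this step.

Going by these compounds, whether a methoxy group or a morpholine ring on this carbon would fall nearer compound 1 or compound 4 remains open. On these data alone, it is also open whether the step carries over to the chain on the pyrazole nitrogen of compound 3.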